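Sulfide and sulfone pairs in a bis(trifluoromethyl)anilide series

The compounds below may be only part of what the source reports. "The series", "measured", "known", "first", "only" and "open" are said of these compounds alone.

Measured compounds:
compound 1 `CC(O)(CSc1ccccc1C(F)(F)F)C(=O)Nc1cc(C(F)(F)F)cc(C(F)(F)F)c1`: 4370 nM
compound 2 `CC(O)(CSc1cccc(OC(F)(F)F)c1)C(=O)Nc1cc(C(F)(F)F)cc(C(F)(F)F)c1`: 6420 nM
compound 3 `CC(O)(CS(=O)(=O)c1ccccc1C(F)(F)F)C(=O)Nc1cc(C(F)(F)F)cc(C(F)(F)F)c1`: 9450 nM

All three were tested in a functional assay on CWR22R cells (Homo sapiens) for antiproliferative activity, read by fluorescence and propidium iodide staining, with a stated time of 96 h; on this read-out higher numbers stand for weaker inhibition and lower numbers for stronger inhibition. Compound 4 `CC(O)(CS(=O)(=O)c1cccc(OC(F)(F)F)c1)C(=O)Nc1cc(C(F)(F)F)cc(C(F)(F)F)c1` has not yet been measured.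

Compound 2 differs from compound 1 by 3-(trifluoromethoxy)phenyl in place of 2-(trifluoromethyl)phenyl on a sulfur. In this assay the step is a 1.5-fold higher number from compound 1 to compound 2 (0.17 log units; within the scatter), so the two values cannot be told apart. Compound 3 carries the same 2-(trifluoromethyl)phenyl group as compound 1, but the difference between the two cores is not broken down here; its number stands beyond the scatter from compound 1, while its gap to compound 2 is within the scatter.

Compound 4 differs from compound 3 by 3-(trifluoromethoxy)phenyl in place of 2-(trifluoromethyl)phenyl on a sulfonyl sulfur. This is the same kind of change as from compound 1 to compound 2, but not the same: in compound 3 the group sits on a sulfonyl sulfur whose other neighbours are a saturated chain carbon, whereas in compound 1 it sits on a sulfur whose other neighbours are a saturated chain carbon. Going by the values given here, only one earlier instance exists, so the expectation is loose. The step from compound 3 to compound 4 is expected to be a 1.5-fold higher number from compound 3 to compound 4 (0.17 log units; within the scatter), resting on the earlier step of a 1.5-fold higher number from compound 1 to compound 2 (0.17 log units; within the scatter). Compound 4 is therefore estimated at 14000 nM, with a likely range from 7000 nM to 30000 nM.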

Compound 4, half-maximal inhibitory concentration: 12800 nM
The estimate for compound 4 lay 1.1-fold (0.04 log units) above the measured number; the range from low to high includes it.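

In this assay, 3-(trifluoromethoxy)phenyl in place of 2-(trifluoromethyl)phenyl on a sulfonyl sulfur gives a 1.4-fold higher number from compound 3 to compound 4 (0.13 log units; within the scatter). Set beside the same change on the sulfur of compound 1, the step carries over between the two cores with no difference that can be told from scatter: the same change on two cores in this assay, a 1.5-fold higher number (0.17 log units; within the scatter) from compound 1 to compound 2 and a 1.4-fold higher number (0.13 log units; within the scatter) from compound 3 to compound 4, 1.1-fold (0.04 log units) apart, within the scatter of two such steps. Neither step lies beyond the scatter, so the two pairs show no effect of the change itself in either core, and they give no rule for other cores or for other groups on the sulfur.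

The compounds shown leave open how a sulfoxide in place of the sulfide or sulfonyl sulfur, or a phenyl carrying an amine or a carboxylic acid, would read in this assay. They also leave open whether the two steps would still agree on a core with a nitrile in place of a trifluoromethyl group on the anilide ring.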